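Pendant phenyl swaps on a shared pyrazolopyridine-free core series

The source may report more compounds than this note shows. Statements on the series, on what has been measured and on what is new or still open speak of the compounds shown alone.

Measured so far:
compound 1, `CCCS(=O)(=O)Nc1ccc(F)c(C(=O)c2n[nH]c3ncc(-c4ccc(O)cc4)cc23)c1F`: 0.75%
compound 2, `CCCS(=O)(=O)Nc1ccc(F)c(C(=O)c2n[nH]c3ncc(-c4ccc(Cl)c(Cl)c4)cc23)c1F`: 45%
compound 3, `CCCS(=O)(=O)Nc1ccc(F)c(C(=O)c2n[nH]c3ncc(-c4ccc(F)cc4C)cc23)c1F`: 14%

In an assay for binding affinity to dual specificity mitogen-activated protein kinase kinase 4 (Homo sapiens), read by KINOMEscan, tested at 100 nM (on this read-out lower numbers stand for a stronger effect and higher numbers for a weaker effect at the one concentration tested), compound 3 stands second highest of the three numbers, separated by a number 13.3 percentage points higher from compound 1 to compound 3 (beyond the scatter) and by a number 31 percentage points lower from compound 2 to compound 3 (beyond the scatter). Compound 4 is `CCCS(=O)(=O)Nc1ccc(F)c(C(=O)c2n[nH]c3ncc(-c4ccc(S(N)(=O)=O)cc4Cl)cc23)c1F`; it differs from compound 3 by 2-chloro-4-sulfamoylphenyl in place of 4-fluoro-2-methylphenyl on an aromatic carbon. Both measured steps on this aromatic carbon bear on it: a number 44.3 percentage points higher from compound 1 to compound 2 (beyond the scatter) and a number 13.3 percentage points higher from compound 1 to compound 3 (beyond the scatter) show the pendant ring moving the read-out widely, with compound 1 giving the lowest number. Compound 4 again brings in a group with a hydrogen-bond donor, as compound 1 does, so a lower number than compound 3 is expected; the estimated step is a number 9 percentage points lower from compound 3 to compound 4 (within the scatter). For compound 4 the expected value is 5%, range 0.5% to 30%.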

Compound 4, a percentage reported as activity, at one concentration (the size of the read-out at that concentration, not a potency): 3.4%
The estimate for compound 4 lay 1.6 percentage points above the measured number, and the stated range covers the measured number.
By their numbers in this assay, from the lowest: compounds 1 and 4 (each within the scatter of the next); then compound 3; then compound 2.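

Placing 2-chloro-4-sulfamoylphenyl where compound 1 has 4-hydroxyphenyl gives, in this assay, a number 2.7 percentage points higher from compound 1 to compound 4 (within the scatter), so a second, differently built ring with a hydrogen-bond donor reads level with compound 1. The same ring gives a number 10.6 percentage points lower from compound 3 to compound 4 (beyond the scatter) and a number 41.6 percentage points lower from compound 2 to compound 4 (beyond the scatter), and across these four compounds the two rings with a donor give the lower numbers, with none going against this. No measured evidence accounts for this. On these data alone, the separate shares of the chlorine and the sulfamoyl group in compound 4 remain open, as both change together. As far as these compounds go, whether a carboxylic acid or an amine in place of the sulfamoyl group would read the same is also open.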